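The source may report more compounds than this note shows. Statements on the series, on what has been measured and on what is new or still open speak of the compounds shown alone.

Compound 1, `N=C(N)NCCC[C@H](NC(=O)CN(c1nc(Cl)nc2[nH]cnc12)C1CC1)C(=O)O`: 17%
Compound 2, `O=C(OCc1ccccc1)[C@@H]1CCCN1C(=O)CN(c1ncnc2c1ncn2C1CCCCO1)C1CC1`: 17.5%

Of the compounds shown here, two have been measured in a functional assay on the whole organism (Tail, strain ICR) with Mus musculus as the target, in the tail flick test, with a stated time of 120 min, at a dose of 25 umol/kg by the oral route; a higher number here means a stronger effect of the compound at the dose given, a lower number a weaker effect. Compound 1 gives 17% in this assay, and compound 2 gives 17.5%. Compound 1 holds the lowest of the two numbers, but the gap to compound 2 lies within the scatter of repeated measurements, so the two readings cannot be told apart.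

The next compound, compound 3, `C[C@H](NC(=O)CN(c1nc(Cl)nc2[nH]cnc12)C1CC1)C(=O)O`, is not yet measured. Its structure differs from that of compound 1 in one way: a hydrogen atom in place of a group of 6 heavy atoms (3 carbon, 3 nitrogen; no ring), on a saturated chain carbon, two bonds along the chain from an amide-type nitrogen and a carbonyl carbon. A hydrogen thus replaces a group of 6 heavy atoms, three carbon and three nitrogen, on a saturated chain carbon two bonds along the chain from an amide-type nitrogen and a carbonyl carbon.

Among the measured compounds shown here, no step between measured compounds is available to guide the size of this change. With both measured readings close together and modest, the step of a number 5 percentage points lower from compound 1 to compound 3 (within the scatter) is expected to be small, if anything slightly downward, and plausibly not beyond the scatter. Compound 3 is therefore estimated at 12% in this assay, within a range from 0% to 30%.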

Compound 3, a percentage reported as activity, at one dose (the size of the read-out at that dose, not a potency): 28.4%
For compound 3 the middle estimate is 16.4 percentage points below the measured one; the measured number falls inside the stated range.
By their numbers in this assay, from the lowest: compounds 1 and 2 (each within the scatter of the next); then compound 3.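

Among the compounds shown here, the step gives the first reading at this position. In this assay the group of 6 heavy atoms (3 carbon, 3 nitrogen; no ring), on a saturated chain carbon, is replaced by a single hydrogen atom, and this gives a number 11.4 percentage points higher from compound 1 to compound 3 (beyond the scatter) and lies beyond the scatter, though it is modest in size. So on this core the whole group can go without any loss of effect at this dose, and the compound without it reads higher, which is a read-out of effect size at one dose and time, not of potency. No measurement of any other property comes with these compounds, so nothing here explains the rise.

A single step also cannot separate the loss of the whole chain end from the loss of any one part of it, so the compounds shown do not say whether a smaller group in the same place, such as a primary amine or a hydroxyl group, would read like compound 1 or like compound 3. Going by these compounds, a longer chain ending in a carboxylic acid at this position is equally open, as is whether the same replacement would give a step of similar size at other doses or times.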